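Cytotoxicity after a substituent swap on a shared amine nitrogen

The source may report more compounds than this note shows. Statements on the series, on what has been measured and on what is new or still open speak of the compounds shown alone.

Compound 1 `CCOC(=O)NC(=O)NC1=CS(=O)(=O)O[C@@]12[C@@H](CO[Si](C)(C)C(C)(C)C)O[C@@H](n1cc(C)c(=O)n(C)c1=O)[C@@H]2O[Si](C)(C)C(C)(C)C` and compound 2 `Cc1cn([C@@H]2O[C@H](CO[Si](C)(C)C(C)(C)C)[C@@]3(OS(=O)(=O)C=C3NCC(=O)OCc3ccccc3)[C@H]2O[Si](C)(C)C(C)(C)C)c(=O)n(C)c1=O` share one core and differ only in what sits on an amine nitrogen. In a functional assay on HEL cells (Homo sapiens) for cytotoxicity, read by microscopy (on this read-out lower numbers stand for higher toxicity in this test and higher numbers for lower toxicity in this test), compound 1 gives 16000 nM. For compound 2 this assay reports only a limit of >= 400000 nM, not a number. Among the measured compounds shown here, the single measured step, an at least 25-fold higher number from compound 1 to compound 2 (1.39 log units; beyond the scatter), ends at the limit of >= 400000 nM in this assay, at which 1 of the 2 values shown sits, which is where compound 2 stands. Compound 3 `Cc1cn([C@@H]2O[C@H](CO[Si](C)(C)C(C)(C)C)[C@@]3(OS(=O)(=O)C=C3NCCC(N)=O)[C@H]2O[Si](C)(C)C(C)(C)C)c(=O)n(C)c1=O` has not yet been measured; it carries carbamoylmethyl in place of benzyloxycarbonyl on a saturated chain carbon bound to an amine nitrogen. For the measured compounds named here, no measured step covers this particular change, so the expectation rests on compound 2 already sitting at the limit of this assay. The step is expected to be a number no higher from compound 2 to compound 3 (the limit leaves the size open), nothing beyond the scatter. Compound 3 is therefore estimated to give 400000 nM, within 100000 nM to 1000000 nM, and is likely to be reported again only as a limit.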

Compound 3, minimum cytotoxic concentration: >= 80000 nM
Compound 3 was reported as a limit; the forecaster's own chance of this, stated with the estimate: 70%; the middle value is on the limit's open side.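

Compound 3 is reported in this assay only as a limit: the limit of >= 80000 nM in this assay, at which 1 of the 3 values shown sits.

With 2-carbamoylethyl in place of (ethoxycarbonyl)carbamoyl on the amine nitrogen, the result is an at least 5.0-fold higher number from compound 1 to compound 3 (0.69 log units; beyond the scatter). A higher number than that of compound 1 is therefore not tied to benzyloxycarbonyl and its aromatic ring, since compound 3 carries no ring in this group. The step from compound 2 to compound 3 cannot be read, so benzyloxycarbonyl and carbamoylmethyl cannot be ranked on a saturated chain carbon bound to an amine nitrogen.

As far as these compounds go, how far compound 2 and compound 3 actually stand from compound 1 remains open. Also open, from the compounds shown here alone, is whether an amine or a carboxylic acid in place of carbamoylmethyl at this place would give a similarly high number.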